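A few compounds are considered here, and "the series" means these few. Any claim that something is new, unique, unknown or untested is made for them only; others in the source may bear on it.

Measured so far:
Compound 1 `Cc1ccc(S(=O)(=O)N[C@@H](CC(=O)NC(C)(C)C)C(=O)NCCNC(=O)c2ccccc2)cc1`: > 11000 nM
Compound 2 `COc1cccc(C(=O)NCCNC(=O)[C@H](CC(=O)NC(C)(C)C)NS(=O)(=O)c2ccc(C)cc2)c1`: > 11000 nM
Compound 3 `Cc1ccc(S(=O)(=O)N[C@@H](CC(=O)NC(C)(C)C)C(=O)NCCNC(=O)c2cccc(F)c2)cc1`: > 11000 nM

In an ADME assay on HepG2 cells (Homo sapiens) for cytotoxicity (a lower number here means that less compound is needed, a higher number that more compound is needed for the effect), compound 3 stands at > 11000 nM, which is a limit of the assay and not a number. The other two entries are limits as well, so the series offers no true number yet: the limit of > 11000 nM in this assay, at which 3 of the 3 values shown sit.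

Compound 4 `Cc1ccc(S(=O)(=O)N[C@@H](CC(=O)NC(C)(C)C)C(=O)NCCNC(=O)NCc2ccccc2)cc1` has benzylamino in place of 3-fluorophenyl on a carbonyl carbon. Read one bond further out, ((3-fluorophenyl)carbonyl)amino becomes (benzylcarbamoyl)amino.

The measured steps that bear on this change are small swaps on an aromatic carbon: a step that the two limits leave unreadable from compound 1 to compound 2, a step that the two limits leave unreadable from compound 1 to compound 3 and a step that the two limits leave unreadable from compound 2 to compound 3. None of them has a readable size, and none replaces a whole group as this change does, so they offer only weak guidance.

Resting on (the limit of > 11000 nM in this assay, at which 3 of the 3 values shown sit), no step beyond the scatter is expected in this assay, and compound 4 will most likely be reported only as a limit too. The expected step, a rough one, is a step that the limit leaves unreadable from compound 3 to compound 4. For compound 4 the estimated value is 15000 nM, with an expected range from 8000 nM to 40000 nM.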

Compound 4, half-maximal effective concentration: > 11000 nM
Compound 4 gave a limit, no number (the forecaster's own chance of this, stated with the estimate: 90%); the middle value lies beyond the limit too.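

In this assay compound 4 gives > 11000 nM, which is a limit of the assay and not a number. No step can be read between compound 4 and compound 1, compound 2 or compound 3, because all their entries are limits: the limit of > 11000 nM in this assay, at which 4 of the 4 values shown sit.

The compounds shown leave open how far apart these four compounds truly lie in this assay.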